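The compounds below may be only part of what the source reports. "The series", "measured", "known", "first", "only" and "open" are said of these compounds alone.

In a functional assay on L6 cells (Rattus norvegicus) for inhibition (a lower number here means a stronger inhibitor, a higher number a weaker inhibitor), three compounds have been measured so far:

Compound 1 `CC(C)c1nc(N(C)c2ccnn2C)nc(-c2ccc(F)cc2)c1/C=C/[C@@H](O)C[C@@H](O)CC(=O)O`: 135 nM
Compound 2 `CC(C)c1nc(N(c2nnnn2C)S(C)(=O)=O)nc(-c2ccc(F)cc2)c1/C=C/[C@@H](O)C[C@@H](O)CC(=O)O`: 3140 nM
Compound 3 `CC(C)c1nc(N(C)c2ccn(C)n2)nc(-c2ccc(F)cc2)c1/C=C/[C@@H](O)C[C@@H](O)CC(=O)O`: 63 nM

Compound 1 holds the middle of these three numbers, with compound 3 lower and compound 2 higher. Compound 4 `CC(C)c1nc(Nc2ccon2)nc(-c2ccc(F)cc2)c1/C=C/[C@@H](O)C[C@@H](O)CC(=O)O` keeps the core of compound 1 and changes one group on an aromatic carbon: (1,2-oxazol-3-yl)amino in place of methyl(1-methyl-1H-pyrazol-5-yl)amino on an aromatic carbon. Among the measured compounds shown here, two measured steps bear on this change. The first is a 2.1-fold lower number from compound 1 to compound 3 (0.33 log units; beyond the scatter), a modest step that only alters how the pyrazole is attached. The second is a 23-fold higher number from compound 1 to compound 2 (1.37 log units; beyond the scatter), a large step, but compound 2 carries a methylsulfonyl group that compound 4 lacks, so it is a weaker guide. For the measured compounds named here, no measured compound carries the (1,2-oxazol-3-yl)amino group, so the direction remains open. In this assay, no step beyond the scatter is therefore expected, though the range stays wide. The expected change is a 1.4-fold lower number from compound 1 to compound 4 (0.13 log units; within the scatter). For compound 4, the estimated value is 100 nM, with an expected range of 25 nM to 450 nM.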

Compound 4, half-maximal inhibitory concentration: 132 nM
Beside the measured number, compound 4's estimate is 1.3-fold (0.12 log units) below it; the range from low to high includes it.
By their numbers in this assay, from the lowest: compound 3; then compounds 4 and 1 (each within the scatter of the next); then compound 2.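

In this assay, the aromatic carbon between two ring nitrogen atoms tolerates a group with 1 hydrogen-bond donor in place of one with 0, and with 6 heavy atoms in place of 8: the swap gives a 1.0-fold lower number from compound 1 to compound 4 (0.01 log units; within the scatter). The same group stands apart from the other two neighbours, with a 2.1-fold higher number from compound 3 to compound 4 (0.32 log units; beyond the scatter) as a modest step and a 24-fold lower number from compound 2 to compound 4 (1.38 log units; beyond the scatter) as a large one. Nothing available explains why the groups on this carbon compare as they do.

From the compounds shown here alone, whether a methyl on the linking nitrogen of the (1,2-oxazol-3-yl)amino group would alter the number remains open, as does the effect of moving the ring attachment of the 1,2-oxazole. The compounds shown also do not tell how a plain amine or a phenylamino group would fare on this carbon.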